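Propyl at the isopropyl position of a thiol-bearing core

This account rests on a few compounds, and the source may have more. Where it says the series, first, only, none or still open, it means among the compounds named here.

Measured compounds:
- Compound 1 `CC(C)c1ncn2c(S)nncc12`. In a functional assay for inhibition, with Homo sapiens as the target (a lower number here means a stronger inhibitor, a higher number a weaker inhibitor), compound 1 gives > 48000 nM, which is a limit of the assay rather than a number.
- Compound 2 `Sc1nncc2cncn12`. In this assay compound 2 gives > 48000 nM, again a limit.
- Compound 3 `Cc1ncn2c(S)nncc12`. In this assay compound 3 gives > 48000 nM, also a limit.

Compound 3 therefore stands at the same limit as both of its neighbours: the limit of > 48000 nM in this assay, at which 3 of the 3 values shown sit. As far as these compounds go, the steps among the three cannot be read: a step that the two limits leave unreadable from compound 1 to compound 2, a step that the two limits leave unreadable from compound 1 to compound 3 and a step that the two limits leave unreadable from compound 2 to compound 3 all remain unreadable, so the size of any change from isopropyl to methyl to hydrogen on the aromatic carbon is unknown.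

Compound 4 `CCCc1ncn2c(S)nncc12` differs from compound 3 by ethyl in place of hydrogen on a saturated chain carbon bound to an aromatic carbon; cut one bond further out, this reads methyl to propyl. Going by the values given here, no measured step bears on it in a readable way. Since every measured compound sits at the limit, compound 4 is expected to sit there as well, with no step beyond the scatter: a step that the limit leaves unreadable from compound 3 to compound 4. Compound 4 is estimated at 100000 nM, in a range from 30000 nM to 500000 nM.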

Compound 4, half-maximal inhibitory concentration: > 48000 nM
Compound 4: no number, only a limit; the forecaster's own chance of this, stated with the estimate: 90%; the middle value lies beyond the limit too.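

In this assay compound 4 gives > 48000 nM, a limit of the assay and not a number. Going by these compounds alone, no step from compound 1, compound 2 or compound 3 to compound 4 can be read. The compounds shown leave open how strongly any of the four inhibits, and whether swapping among these groups changes inhibition at all.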